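A few compounds are considered here, and "the series" means these few. Any claim that something is new, unique, unknown or untested is made for them only; others in the source may bear on it.

Measured so far:
compound 1 `Cc1nc(S(C)(=O)=O)ccc1Oc1ncnc(OC2CCN(C(=O)OC(C)(C)C(F)(F)F)CC2)c1F`: 79%
compound 2 `Cc1nc(S(C)(=O)=O)ccc1Oc1ncnc(OC2CCN(C(=S)OC3(C)CC3)CC2)c1F`: 49%

In a functional assay on isolated protein for inhibition of Glucose-dependent insulinotropic receptor (Rattus norvegicus), read by HTRF and cAMP accumulation (on this read-out higher numbers stand for larger maximal responses and lower numbers for smaller maximal responses), compound 1 gives 79% and compound 2 gives 49%; compound 2 thus stands lowest of the two numbers, with compound 1 above it by a number 30 percentage points lower from compound 1 to compound 2 (beyond the scatter). Compound 3 `Cc1nc(S(C)(=O)=O)ccc1Oc1ncnc(OC2CCN(C(=O)C3CCCC3)CC2)c1F` is not yet measured. It differs from compound 2 only on the amine nitrogen in the ring: a group of 7 heavy atoms (6 carbon, 1 oxygen; one five-membered non-aromatic ring of carbon only) in place of a group of 7 heavy atoms (5 carbon, 1 oxygen, 1 sulfur; one three-membered non-aromatic ring of carbon only), on an amine nitrogen in a ring.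

Among the compounds with values here, the only measured step that bears on this position is the one from compound 1 to compound 2, which changed the same nitrogen substituent and moved the read-out by a number 30 percentage points lower from compound 1 to compound 2 (beyond the scatter), a modest shift beyond the scatter. Within the data shown here, no measured pair isolates the change from compound 2 to compound 3 itself, so the direction rests on the observation that this position can move the maximal response modestly. For compound 3 the estimate is 64%, with a range from 40% to 88%. That estimate corresponds to an expected step of a number 15 percentage points higher from compound 2 to compound 3 (beyond the scatter), placing compound 3 between the two measured compounds.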

Compound 3, largest response reached (reported as efficacy), in percent of the reference or control that the assay uses: 83%
The estimate for compound 3 lay 19 percentage points below the measured number, and the stated range covers the measured number.
By their numbers in this assay, from the lowest: compound 2; then compounds 1 and 3 (each within the scatter of the next).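

In this assay, the group on the amine nitrogen in a ring can move the response upward as well as downward: cyclopentylcarbonyl in place of the sulfur-bearing group of compound 2 gives a number 34 percentage points higher from compound 2 to compound 3 (beyond the scatter). Cyclopentyl in place of 1-methyl-1-(trifluoromethyl)ethoxy on the carbonyl carbon gives a number 4 percentage points higher from compound 1 to compound 3 (within the scatter), so in this pair neither that ether-type group nor its fluorine atoms are required to reach this level of response. No measurement at hand accounts for either step.

As far as these compounds go, the step from the sulfur-bearing group changes the sulfur, the oxygen link and the ring size together, so the share of each stays open. Also open, from the compounds shown here alone, is how a cyclohexyl group or an open-chain tert-butyl group on the same carbonyl carbon would read.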